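Aryl for Alkyl on the Cyanoguanidine Nitrogen

The source may report more compounds than this note shows. Statements on the series, on what has been measured and on what is new or still open speak of the compounds shown alone.

The series rests on a shared cyanoguanidine core carrying a pyridinyl group, varied only at the double-bonded nitrogen. Compound 1 `CC(C)CC/N=C(\NC#N)Nc1cccnc1` carries an isopentyl chain there; in a functional assay on the whole organism (blood, strain Wistar-Okamoto) with Rattus norvegicus as the target, with a stated time of 5 days (a higher number here means that more compound is needed for the effect, a lower number that less compound is needed), compound 1 gives 20 mg/kg, the highest of the two numbers recorded so far. Its nearest neighbour, compound 2 `CC(/N=C(/NC#N)Nc1cccnc1)C(C)(C)C`, bears a branched alkyl chain at the same nitrogen and needs far less material: in this assay compound 2 gives 1 mg/kg, a gap that lies well beyond the usual scatter of the measurement.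

Compound 3 `N#CN/C(=N\c1ccccc1)Nc1cccnc1` takes the step from compound 1 in a different direction, with an aromatic group in place of the chain (phenyl in place of isopentyl on a double-bonded nitrogen). Going by the values given here, no measured pair shows what such a change does, and the two alkyl analogues give no guidance on a ring here.

With nothing to anchor a shift, compound 3 is expected to stay close to compound 1, with an estimated change of no change at the digits printed from compound 1 to compound 3 (within the scatter) in this assay. The estimate for compound 3 is therefore 20 mg/kg, within a range from 5 mg/kg to 80 mg/kg.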

Compound 3, minimum effective dose: 5 mg/kg
Estimate against measurement, compound 3: 4.0-fold (0.60 log units) above; the measured number falls inside the stated range.
By their numbers in this assay, from the lowest: compound 2; then compound 3; then compound 1.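

The step shows that the double-bonded nitrogen tolerates more than an alkyl chain: in this assay, phenyl in place of isopentyl gives a 4.0-fold lower number from compound 1 to compound 3 (0.60 log units; beyond the scatter) and the effect is kept with less compound. A six-membered aromatic ring of carbon only therefore serves here as well as a chain, and better than the isopentyl chain, although the branched chain of compound 2 at 1 mg/kg still has a lower number than compound 3 at 5 mg/kg in the same assay. Nothing measured explains why the number falls with this change.

A cyclohexyl group at this nitrogen would separate the presence of a ring from its aromatic character, which this single step cannot do. As far as these compounds go, how a substituted ring such as a chlorophenyl or methoxyphenyl group, or a benzyl group that sets the phenyl one carbon further out, would compare with compound 3 also remains open.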